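Swapping the ring on a thiocarbonyl carbon

The source may hold more compounds than are shown below. What is called first, only, known or untested is meant among the compounds shown, and "the series" means these compounds.

- compound 1 `COc1ccc(-c2coc3cc(OCCCBr)ccc3c2=O)cc1` gives 64900 nM
- compound 2 `COc1ccc(-c2coc3cc(OCCCSC(=S)N4CCN(C(C)=O)CC4)ccc3c2=O)cc1` gives 39400 nM

Both numbers come from a functional assay on MGC-803 cells (Homo sapiens) for inhibition, read by MTT assay, with a stated time of 48 h; a lower number here means a stronger inhibitor, a higher number a weaker inhibitor. The values of compound 1 and compound 2 lie within the usual scatter of each other, so compound 2 stands level with compound 1 on these data.

The next compound, compound 3 `COc1ccc(-c2coc3cc(OCCCSC(=S)N4CCCC4)ccc3c2=O)cc1`, has pyrrolidin-1-yl in place of 4-acetylpiperazin-1-yl on a thiocarbonyl carbon. Within the data shown here, no two measured compounds differ in just one place, so the data do not show what such a swap does. Among the measured compounds shown here, the only close anchor is compound 2 at 39400 nM. No shift beyond the scatter is therefore expected in this assay, in either direction. The expected step is small: a 1.3-fold lower number from compound 2 to compound 3 (0.12 log units; within the scatter). For compound 3 the estimated value is 30000 nM, with an expected range from 12000 nM to 70000 nM.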

Compound 3, half-maximal inhibitory concentration: 40000 nM
For compound 3 the middle estimate is 1.3-fold (0.12 log units) below the measured one; the measured number falls inside the stated range.
By their numbers in this assay, from the lowest: compounds 2, 3 and 1 (each within the scatter of the next).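

In this assay, pyrrolidin-1-yl in place of 4-acetylpiperazin-1-yl on a thiocarbonyl carbon gives a 1.0-fold higher number from compound 2 to compound 3 (0.01 log units; within the scatter). Among these compounds, this gives the first direct reading at this position: the ring can be exchanged for one with fewer heavy atoms and no hydrogen-bond acceptor, with no shift beyond the scatter. The group carrying pyrrolidin-1-yl in place of one bromine atom on the saturated chain carbon also stays level, at a 1.6-fold lower number from compound 1 to compound 3 (0.21 log units; within the scatter), and no other measurement here helps to explain these results.

The compounds shown leave open whether a morpholin-4-yl or piperidin-1-yl ring, or an open-chain dimethylamino group, on the same carbon would move the number beyond the scatter. They also leave open whether a longer chain to the shared core would do so.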